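The compounds below may be only part of what the source reports. "The series", "measured", "known", "first", "only" and "open" are said of these compounds alone.

Measured so far in a physicochemical assay for solubility, in phosphate buffer; on this read-out higher numbers stand for higher solubility and lower numbers for lower solubility

compound 1 `CC(C)C(NC(=O)Cn1c(-c2ccccc2)cc2c(=O)n(CC(N)=O)c(=O)[nH]c2c1=O)C(=O)C(F)(F)F` gives 130 ug/mL
compound 2 `CC(C)C(NC(=O)Cn1c(-c2ccccc2)ccc(NC(=O)OCc2ccncc2)c1=O)C(=O)C(F)(F)F` gives 16 ug/mL

Compound 1 holds the highest of the two numbers, and compound 2 lies beyond the scatter under it. Among the measured compounds shown here, the two compounds do not differ in just one place, so their gap cannot be tied to any single change, and no measured step is available for calibration.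

Next in line is compound 3 `CC(C)C(NC(=O)Cn1c(-c2ccccc2)cc2c(=O)n(N(C)C)c(=O)[nH]c2c1=O)C(=O)C(F)(F)F`, not yet measured. It keeps the core of compound 1 but carries dimethylamino in place of carbamoylmethyl on an aromatic nitrogen. For the measured compounds named here, with no measured step to lean on, the expectation in this assay rests on this structural difference alone and is correspondingly loose. A downward step of moderate size is expected, only slightly beyond the scatter, and a result within the scatter of compound 1 would not be surprising. The estimate is a 2.2-fold lower number from compound 1 to compound 3 (0.34 log units; beyond the scatter) as the size of that step. Compound 3 is estimated at 60 ug/mL with 20 ug/mL to 150 ug/mL as the expected range.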

Compound 3, solubility: 320 ug/mL
The estimate for compound 3 lay 5.3-fold (0.73 log units) below the measured number; measured number outside the range, above it.
By their numbers in this assay, from the lowest: compound 2; then compound 1; then compound 3.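

In this assay, among the compounds shown here, the substituent on this aromatic nitrogen of the shared core now has a measured effect on the number: dimethylamino in place of carbamoylmethyl gives a 2.5-fold higher number from compound 1 to compound 3 (0.39 log units; beyond the scatter) in the first step that can be tied to one place. The change swaps carbamoylmethyl, with 1 hydrogen-bond donor and 1 hydrogen-bond acceptor, for dimethylamino, with 0 hydrogen-bond donors and 1 hydrogen-bond acceptor, with no ring and no net charge on either side, but this single step cannot separate those differences from one another. No measurement at hand bears on why the number moves.

For the compounds shown here, only two groups on this nitrogen can be compared, so it remains open whether the higher number follows dimethylamino itself or the loss of carbamoylmethyl, and a methyl group, a longer alkyl chain or a carboxylic acid at the same place would help to separate these readings. On these data alone, compound 2 differs from the other two compounds in more than one place, so its steps cannot be read, and whether this change would carry over to other members also remains open.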